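This account rests on a few compounds, and the source may have more. Where it says the series, first, only, none or still open, it means among the compounds named here.

Measured compounds in an assay on CHO cells for displacement of a labelled ligand from prostaglandin D2 receptor 2 (Homo sapiens), read by scintillation counting; on this read-out higher numbers stand for weaker inhibition and lower numbers for stronger inhibition:
- compound 1 `Cc1ccc(S(=O)(=O)Cc2ccccc2)cc1C#Cc1cc(Cl)ccc1OCC(=O)O`: 5 nM
- compound 2 `CCCS(=O)(=O)c1cccc(C#Cc2c(Cl)cccc2OCC(=O)O)c1`: 55 nM

Compound 1 stands at the lowest number of the two measured compounds in this assay, and compound 2 sits at a higher number, with a gap between the two that lies beyond the usual scatter of repeated measurements; on this read-out compound 1 is therefore the stronger inhibitor of the pair.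

Compound 3 `Cc1ccc(S(=O)(=O)CCO)cc1C#Cc1cc(Cl)ccc1OCC(=O)O` has not yet been measured. It differs from compound 1 in one place: hydroxymethyl in place of phenyl on a saturated chain carbon bound to a sulfonyl sulfur. Going by the values given here, no measured pair in this set shows the effect of exactly this change, so the expectation for compound 3 rests on where compound 1 stands and on the size of the change itself.

The replacement of a six-membered aromatic ring by a much smaller, donor-bearing group is a sizeable change, and the step from compound 1 to compound 3 is expected to be a loss of inhibition of moderate size, a 4.0-fold higher number from compound 1 to compound 3 (0.60 log units; beyond the scatter), beyond the scatter. For compound 3 in this assay the estimate is 20 nM, within a range from 5 nM to 80 nM.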

Compound 3, inhibition constant: 19 nM
The estimate for compound 3 lay 1.1-fold (0.02 log units) above the measured number; measured number inside the range.
By their numbers in this assay, from the lowest: compound 1; then compound 3; then compound 2.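

In this assay, going by these compounds alone, putting hydroxymethyl in place of phenyl on a saturated chain carbon bound to a sulfonyl sulfur gives a 3.8-fold higher number from compound 1 to compound 3 (0.58 log units; beyond the scatter), the first direct reading of a change at this position. The step is modest and beyond the scatter, and compound 3 still gives 19 nM, so in this series a six-membered aromatic ring at this position is not required for measurable inhibition, though the compound with the ring, compound 1, gives the lower number. No measurement shown here accounts for the size of this step.

The compounds shown leave open how much of the step belongs to the loss of the phenyl and how much to the entry of the hydroxymethyl; a plain ethyl group, a 2-aminoethyl group or a carboxylic acid on the same chain would begin to separate the two. On these data alone, compound 2 differs from compound 1 in more than one place, so it cannot settle this, and whether the same step would hold on the core of compound 2 also remains open.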